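The compounds below may be only part of what the source reports. "The series", "measured", "known", "first", "only" and "open" are said of these compounds alone.

Compound 1 `Brc1ccc(NC2=NCCC3(CCCCC3)S2)cc1` gives 1.36 in a physicochemical assay for lipophilicity, at pH 7.4; on this read-out higher numbers stand for higher lipophilicity and lower numbers for lower lipophilicity.
Compound 2 `CCc1ccc(NC2=NCCC3(CCCCC3)S2)cc1` gives 1.75.
Compound 3 `c1ccc(NC2=NCCC3(CCCCC3)S2)cc1` gives 1.69.

Among these three numbers compound 3 stands second highest. Its nearest neighbour is compound 2, with a number 0.06 log units lower from compound 2 to compound 3 (within the scatter), a gap within the scatter, so no order can be read between those two. Its furthest neighbour is compound 1, with a number 0.33 log units higher from compound 1 to compound 3 (beyond the scatter), a modest step beyond the scatter, and a number 0.39 log units higher from compound 1 to compound 2 (beyond the scatter) is of the same kind. All three measured steps concern only the group sitting on an aromatic carbon.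

Compound 4 `CNC1=NCCC2(CCCCC2)S1` is the next compound to be measured, and it differs from compound 3 in another place: methyl in place of phenyl on an amine nitrogen. For the measured compounds named here, none of the measured steps touches the amine nitrogen, so they give no direct guide to this change. What remains is what leaves and what enters: a phenyl ring gives way to a methyl group, a far larger change in size than any of the measured steps. A drop in this assay well beyond the scatter is therefore expected for compound 4. The step expected from compound 3 to compound 4 is a number 1.49 log units lower from compound 3 to compound 4 (beyond the scatter). Compound 4 is thus estimated at 0.2, within a range from -0.5 to 0.9.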

Compound 4, distribution coefficient: 0.91
For compound 4 the middle estimate is 0.71 log units below the measured one, outside the stated range (above it).
By their numbers in this assay, from the lowest: compound 4; then compound 1; then compounds 3 and 2 (each within the scatter of the next).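

In this assay, for the compounds shown here, methyl in place of phenyl on the amine nitrogen gives a number 0.78 log units lower from compound 3 to compound 4 (beyond the scatter), so the group at this nitrogen moves the read-out, whereas the earlier steps changed only the group on an aromatic carbon and left the phenyl ring in place. The change is large in structural terms, with a phenyl of 6 heavy atoms giving way to a methyl of 1 heavy atom, yet the step is still modest, the same class as a number 0.33 log units higher from compound 1 to compound 3 (beyond the scatter). Nothing among the data shown accounts for why the step has this size.

With only phenyl and methyl on this nitrogen, the compounds shown cannot separate the effect of losing the aromatic ring from the effect of losing carbon atoms in general. On these data alone, a butyl chain or a cyclohexyl ring on the same nitrogen would help to tell these two readings apart, and it also remains open how far the order seen among the ring-bearing compounds would hold for other groups at this place.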